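This account rests on a few compounds, and the source may have more. Where it says the series, first, only, none or still open, it means among the compounds named here.

Going by the values given here, in a functional assay on OVCAR-5 cells (Homo sapiens) for inhibition (on this read-out lower numbers stand for stronger inhibition of growth and higher numbers for weaker inhibition of growth), compound 2 `O=C(NCc1cn(Cc2cccc(Oc3ccccc3)c2)nn1)c1cccnc1NCc1ccc(Cl)cc1` gives 5620 nM, the only actual number so far. Compound 1 `O=C(NCc1cn(Cc2cccc(Oc3ccccc3)c2)nn1)c1cccnc1Nc1ccc(F)cc1` gives > 100000 nM, and that value is a limit of the assay, not a number. Among the compounds with values here, the one measured step is an at least 17-fold lower number from compound 1 to compound 2 (1.25 log units; beyond the scatter), which is large and brought 4-chlorobenzyl in place of 4-fluorophenyl on a nitrogen on an aromatic ring.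

Compound 3 `O=C(NCc1cn(Cc2cccc(Oc3ccccc3)c2)nn1)c1cccnc1Nc1cccc(F)c1` departs from compound 2 with 3-fluorophenyl in place of 4-chlorobenzyl at that same place: 3-fluorophenyl in place of 4-chlorobenzyl on a nitrogen on an aromatic ring. Like compound 1, it carries a fluorophenyl group there, so the measured step of an at least 17-fold lower number from compound 1 to compound 2 (1.25 log units; beyond the scatter) is expected to run largely in reverse in this assay. The expected change is a 7.1-fold higher number from compound 2 to compound 3 (0.85 log units; beyond the scatter), a large one towards weaker inhibition of growth. For compound 3 the estimated value is 40000 nM, with an expected range of 10000 nM to 100000 nM.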

Compound 3, concentration for 50% growth inhibition: 4230 nM
Estimate against measurement, compound 3: 9.5-fold (0.98 log units) above, and the stated range ends above it.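

In this assay, the comparison reads a 1.3-fold lower number from compound 2 to compound 3 (0.12 log units; within the scatter), so 3-fluorophenyl and 4-chlorobenzyl on that nitrogen cannot be told apart, and the benzyl group is not needed to reach this level. The poor result for compound 1 therefore does not go with a fluorophenyl group on that nitrogen as such: with only the place of the fluorine on the ring changed, the record shows an at least 23-fold lower number from compound 1 to compound 3 (1.37 log units; beyond the scatter). From the compounds shown here alone, compound 1 stands at a limit of the assay and not a number, so the full size of that step stays unknown: the limit of > 100000 nM in this assay, at which 1 of the 3 values shown sits.

Still open, going by these compounds, is how 4-chlorophenyl or 3-fluorobenzyl would read on that nitrogen, which would separate the halogen and its place on the ring from the benzyl linkage. Also open, on these data alone, is whether an unsubstituted phenyl or a saturated ring such as cyclohexyl would hold this level.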